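This account rests on a few compounds, and the source may have more. Where it says the series, first, only, none or still open, it means among the compounds named here.

Working notes on the series. Two compounds have numbers in a functional assay on MIA PaCa-2 cells (Homo sapiens) for inhibition, read by MTT assay, with a stated time of 3 days; a lower number here means a stronger inhibitor, a higher number a weaker inhibitor. Compound 1 `CC(C)S(=O)(=O)c1ccc(S(=O)(=O)N2CCC[C@@H](C(=O)N3CCC(F)(F)CC3)C2)cc1` gives 9.1 nM in this assay. Compound 2 `CCN(CC)S(=O)(=O)c1ccc(S(=O)(=O)N2CCC[C@@H](C(=O)N[C@H]3CCOC3)C2)cc1` gives 290 nM in this assay, the higher of the two numbers, and the gap to compound 1 lies beyond the scatter. Going by the values given here, compound 1 and compound 2 differ from each other in more than one place, so no single structural step connects the two values; they are given side by side only.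

The next compound, compound 3 `CCN(CC)S(=O)(=O)c1ccc(S(=O)(=O)N2CCC[C@@H](C(=O)N3CC[C@@H](OC)C3)C2)cc1`, is built from compound 2 by one change: 3-methoxypyrrolidin-1-yl in place of (oxolan-3-yl)amino on a carbonyl carbon. The ring that leaves and the ring that enters are both five-membered and each holds one hetero atom; what changes is the point at which the ring is attached to the carbonyl and the loss of the hydrogen-bond donor.

Among the compounds with values here, no measured pair shows this change on its own, so the direction of the step is an open question. A move toward the lower numbers is expected, of moderate size, as a 2.6-fold lower number from compound 2 to compound 3 (0.42 log units; beyond the scatter), since the only other amide type in the set, that of compound 1, sits at 9.1 nM. For compound 3 the estimate in this assay is 110 nM, with a range of 30 nM to 400 nM.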

Compound 3, half-maximal inhibitory concentration: 1070 nM
The estimate for compound 3 lay 9.7-fold (0.99 log units) below the measured number; measured number outside the range, above it.
By their numbers in this assay, from the lowest: compound 1; then compound 2; then compound 3.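

In this assay, going by these compounds alone, 3-methoxypyrrolidin-1-yl in place of (oxolan-3-yl)amino on a carbonyl carbon gives a 3.7-fold higher number from compound 2 to compound 3 (0.57 log units; beyond the scatter), the first single-change reading at this position, and the number moves up. The two groups each carry one five-membered non-aromatic ring with 1 hetero atom, yet the entering group has 0 hydrogen-bond donors against 1 hydrogen-bond donor in the leaving group, so this position does not tolerate the exchange without a measurable change in this assay. No measured evidence on the compounds explains the rise in the number.

The step changes the ring attachment, the amide hydrogen and the methoxy group together, so the compounds shown do not say which of these goes with the higher number, and methyl(oxolan-3-yl)amino or unsubstituted pyrrolidin-1-yl on the same carbonyl carbon would separate them. On these data alone, compound 1 differs from compound 2 and compound 3 in more than one place, so it remains open how 4,4-difluoropiperidin-1-yl on that carbonyl carbon would read on the diethylsulfamoyl side of the series.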